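Swapping an amine tail and expected cell tolerance

The source may hold more compounds than are shown below. What is called first, only, known or untested is meant among the compounds shown, and "the series" means these compounds.

Three compounds sharing the same core were tested in an ADME assay on MDBK cells (Bos taurus) for cytotoxicity, read by MTT assay, with a stated time of 96 h; a lower number here means that less compound is tolerated, a higher number that more compound is tolerated. Compound 1 `CN1CCN(CC(=O)Nc2ccc(-c3nc4cc(C(F)(F)F)ccc4n3C)cc2)CC1` gives 44000 nM in this assay. Compound 3 `O=[N+]([O-])c1ccc(-c2nc3cc(C(F)(F)F)ccc3[nH]2)cc1` gives 6000 nM in this assay. Of the two numbers shown, compound 1 stands highest, and its gap to compound 3 lies beyond the usual scatter. Compound 2 `COc1ccc(-c2nc3cc(C(F)(F)F)ccc3[nH]2)c(OC)c1` reached only a limit of this assay, > 100000 nM, so no number is known for it (the limit of > 100000 nM in this assay, at which 1 of the 3 values shown sits).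

Compound 4 `CCN(CC)CC(=O)Nc1ccc(-c2nc3cc(C(F)(F)F)ccc3n2C)cc1` has not yet been measured. It differs from compound 1 in a single place: diethylamino in place of 4-methylpiperazin-1-yl on a saturated chain carbon bound to a carbonyl carbon. The 4-methylpiperazin-1-yl group leaves and a diethylamino group enters, on a saturated chain carbon bound to a carbonyl carbon. Among the measured compounds shown here, no measured pair here shows what such a swap does, so the step is expected to be small, either within the scatter or a modest move toward less tolerance. The estimated step of a 1.3-fold lower number from compound 1 to compound 4 (0.10 log units; within the scatter) reflects this. Compound 4 is therefore expected to give about 35000 nM in this assay, plausibly between 12000 nM and 100000 nM.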

Compound 4, half-maximal cytotoxic concentration: 57000 nM
Beside the measured number, compound 4's estimate is 1.6-fold (0.21 log units) below it; the range from low to high includes it.
By their numbers in this assay, from the lowest: compound 3; then compounds 1 and 4 (each within the scatter of the next). At a limit, above all of these: compound 2.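

In this assay, placing diethylamino where 4-methylpiperazin-1-yl stood, on a saturated chain carbon bound to a carbonyl carbon, gives a 1.3-fold higher number from compound 1 to compound 4 (0.11 log units; within the scatter). Among the compounds shown here, this is the first direct view of a change at this position: an open tail with no ring and a six-membered ring with two hetero atoms are tolerated alike by these cells, as far as this single pair can show. Nothing in the data at hand accounts for this close match between the two tails.

As far as these compounds go, one swap cannot show how much the tail matters in general, so it remains open whether a morpholine ring or a carboxylic acid at this place would also stay within the scatter. Compound 2 and compound 3 differ from this pair in more than one place, so they cannot settle that question.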